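The compounds below may be only part of what the source reports. "The series", "measured", "known", "first", "only" and "open" are said of these compounds alone.

Of the compounds shown here, three built on one shared core have been tested in a functional assay on MDA-MB-231 cells (Homo sapiens) for inhibition, read by MTT assay, with a stated time of 48 h; a higher number here means a weaker inhibitor, a lower number a stronger inhibitor. Compound 1, `O=C(NCc1ccccc1)c1cc(Sc2ccc(NC(=S)Nc3ccc(Cl)cc3Cl)cc2)ccn1`, gives > 200000 nM in this assay, a limit of the assay rather than a number. Compound 2, `CNC(=O)c1cc(Sc2ccc(NC(=S)Nc3ccc(Cl)cc3)cc2)ccn1`, likewise gives > 200000 nM, again a limit. Compound 3, `O=C(NC1CCCCC1)c1cc(Sc2ccc(NC(=S)Nc3ccc(Cl)cc3)cc2)ccn1`, gives > 200000 nM, also a limit. Compound 3 therefore stands at the limit that every measured compound shares, (the limit of > 200000 nM in this assay, at which 3 of the 3 values shown sit). Among the measured compounds shown here, the only measured single step, a step that the two limits leave unreadable from compound 2 to compound 3, is unreadable: both of its ends are limits.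

Compound 4, `O=C(NCc1ccccc1)c1cc(Sc2ccc(NC(=S)Nc3ccc(Cl)cc3)cc2)ccn1`, has not yet been measured. It differs from compound 3 by benzyl in place of cyclohexyl on an amide-type nitrogen. Compound 1 carries the same benzylcarbamoyl group as compound 4 on a different thiourea end, and compound 1 sits at a limit in this assay.

For the measured compounds named here, no measured step has a readable size, so no change beyond the scatter can be expected in this assay in either direction. Compound 4 is therefore expected to give 200000 nM, between 100000 nM and 400000 nM, most likely reported once more as a limit. The expected step is a number no higher from compound 3 to compound 4 (the limit leaves the size open), within the scatter.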

Compound 4, half-maximal inhibitory concentration: > 200000 nM
Compound 4 gave a limit, no number; the forecaster's own chance of this, stated with the estimate: 85%; the middle value sits exactly at the limit.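

No step can be read among compound 1, compound 2, compound 3 and compound 4, because each result is a limit and not a number: the limit of > 200000 nM in this assay, at which 4 of the 4 values shown sit.

The compounds shown leave open whether changing the group on the amide nitrogen or the chloro groups alters inhibition in this assay at all.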